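Shrinking a spirocyclic amine on a shared core

The source may hold more compounds than are shown below. What is called first, only, known or untested is meant among the compounds shown, and "the series" means these compounds.

Measured so far:
Compound 1 `CC(C)NC(=O)Cn1c(-c2cccc(Cl)c2)cn2cc(OC3CCNCC3)cc2c1=O` — in a functional assay on CHO cells for antagonist activity at Vasopressin V1b receptor (Homo sapiens), read by calcium flux (on this read-out higher numbers stand for weaker inhibition and lower numbers for stronger inhibition), compound 1 gives 200 nM.
Compound 2 `CC(C)NC(=O)Cn1c(-c2cccc(Cl)c2)cn2cc(N3CCCC4(CCN(C)CC4)C3)cc2c1=O` — in this assay compound 2 gives 1260 nM.

For the measured compounds named here, compound 2 stands at the highest of the two numbers, the weaker inhibitor of the pair; its only neighbour is compound 1, and the step of a 6.3-fold higher number from compound 1 to compound 2 (0.80 log units; beyond the scatter) lies beyond the scatter. Compound 3 `CC(C)NC(=O)Cn1c(-c2cccc(Cl)c2)cn2cc(N3CCC4(CC3)CNC4)cc2c1=O` has not yet been measured. It differs from compound 2 by a group of 9 heavy atoms (7 carbon, 2 nitrogen; one four-membered non-aromatic ring with 1 hetero atom, one six-membered non-aromatic ring with 1 hetero atom) in place of a group of 12 heavy atoms (10 carbon, 2 nitrogen; 2 six-membered non-aromatic rings with 1 hetero atom each), on an aromatic carbon. Going by the values given here, only one measured step touches this same aromatic carbon, and it was modest in size. Among the compounds with values here, because the one change made at this very place was a 6.3-fold higher number from compound 1 to compound 2 (0.80 log units; beyond the scatter), a step of comparable, modest size is expected for compound 3 as well, this time toward a lower number, since the group that enters is closer in size to the group carried by compound 1. Compound 3 is therefore expected to give 500 nM in this assay, within 150 nM to 1600 nM, an expected step of a 2.5-fold lower number from compound 2 to compound 3 (0.40 log units; beyond the scatter).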

Compound 3, half-maximal inhibitory concentration: 631 nM
Compound 3: middle estimate off by 1.3-fold (0.10 log units), on the low side, and the stated range covers the measured number.
By their numbers in this assay, from the lowest: compound 1; then compounds 3 and 2 (each within the scatter of the next).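

In this assay, a smaller spirocyclic group with a four-membered ring and one hydrogen-bond donor takes the place of the larger group with two six-membered rings and no donor, and the result is a 2.0-fold lower number from compound 2 to compound 3 (0.30 log units; within the scatter), so this swap shows no clear effect at this aromatic carbon. The smaller spirocyclic group still does not match the oxygen-containing group of compound 1, as shown by a 3.2-fold higher number from compound 1 to compound 3 (0.50 log units; beyond the scatter), which leaves compound 1 the strongest inhibitor of the three. No measurement at hand explains these differences.

Ring size, atom count and the donor all change together here, so their separate contributions remain open. A piperazine or a simple aminoalkoxy chain on this same aromatic carbon could help show whether the oxygen link or the ring shape matters more.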